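This account rests on a few compounds, and the source may have more. Where it says the series, first, only, none or still open, it means among the compounds named here.

Measured so far in a functional assay on 518A2 cells (Homo sapiens) for cytotoxicity, read by MTT assay, with a stated time of 72 h; a higher number here means a weaker inhibitor, a lower number a stronger inhibitor:
- compound 1 `CN1C/C(=C\c2cc(F)c(F)cc2F)C(=O)/C(=C/c2cc(F)c(F)cc2F)C1`: 1600 nM
- compound 3 `CCN1C/C(=C\c2cc(F)c(F)cc2F)C(=O)/C(=C/c2cc(F)c(F)cc2F)C1`: 1500 nM
- compound 2 `CN1C/C(=C\c2c(F)cc(F)cc2F)C(=O)/C(=C/c2c(F)cc(F)cc2F)C1`: > 10000 nM, a limit of this assay, not a number

Compound 2 sits at the limit of > 10000 nM in this assay, at which 1 of the 3 values shown sits. Compound 1 and compound 2 are built from the same atoms joined differently; the difference between the two cores is not broken down here.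

The change from compound 1 to compound 3 is methyl in place of hydrogen on a saturated chain carbon bound to an amine nitrogen in a ring. Its step is a 1.1-fold lower number from compound 1 to compound 3 (0.03 log units; within the scatter).

Compound 4 `CCN1C/C(=C\c2c(F)cc(F)cc2F)C(=O)/C(=C/c2c(F)cc(F)cc2F)C1` is not yet measured in this assay. It differs from compound 2 by methyl in place of hydrogen on a saturated chain carbon bound to an amine nitrogen in a ring, the same change at the same place as that from compound 1 to compound 3.

For compound 4 the expectation rests on compound 1 and compound 3, whose step a 1.1-fold lower number from compound 1 to compound 3 (0.03 log units; within the scatter) is within the scatter, so the step from compound 2 to compound 4 is expected to be about as small, a step that the limit leaves unreadable from compound 2 to compound 4. Since compound 2 reports only a limit, compound 4 is expected most likely to report only a limit as well. The estimate for compound 4 is 15000 nM, with a likely range of 7000 nM to 40000 nM.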

Compound 4, half-maximal inhibitory concentration: 2000 nM
Estimate against measurement, compound 4: 7.5-fold (0.88 log units) above; measured number outside the range, below it.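

In this assay, methyl in place of hydrogen on a saturated chain carbon bound to an amine nitrogen in a ring gives an at least 5.0-fold lower number from compound 2 to compound 4 (0.69 log units; beyond the scatter), so the size of this step does not carry over from the core of compound 1 to the core of compound 2: the same change on two cores in this assay, a 1.1-fold lower number (0.03 log units; within the scatter) from compound 1 to compound 3 and an at least 5.0-fold lower number (0.69 log units; beyond the scatter) from compound 2 to compound 4, at least 4.6-fold (0.67 log units) apart, beyond the scatter of two such steps. From the compounds shown here alone, compound 2 gives > 10000 nM, which is a limit of the assay and not a number, so the full size of this step remains unknown and only its stated minimum can be read: the limit of > 10000 nM in this assay, at which 1 of the 4 values shown sits. The two pairs show that the effect of the change differed between these two cores, but they do not show why, and they give no rule for any other core.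

Going by these compounds, it remains open whether a longer chain, such as propyl, at the same place would follow the step seen on the core of compound 1 or the step seen on the core of compound 2. A cyclopropyl group at that place is also untested among the compounds shown.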